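The source may hold more compounds than are shown below. What is called first, only, known or untested is meant among the compounds shown, and "the series" means these compounds.

In a functional assay on HeLa cells (Homo sapiens) for inhibition, read by MTT assay, with a stated time of 48 h (a higher number here means a weaker inhibitor, a lower number a stronger inhibitor), compound 3 (`N#Cc1ccc2[nH]cc(C(c3ccc(Cl)cc3)c3c[nH]c4ccc(C#N)cc34)c2c1`) reads > 100000 nM, which is a limit and not a number. Compound 4 (`CCCCCCCC(c1c[nH]c2ccc(C#N)cc12)c1c[nH]c2ccc(C#N)cc12`) differs from it as follows: heptyl in place of 4-chlorophenyl on a saturated chain carbon bound to two aromatic carbons. For the measured compounds named here, one measured step bears on this change. In this assay, compound 1 (`COc1ccc(C(c2c[nH]c3ccc(Br)cc23)c2c[nH]c3ccc(Br)cc23)c(OC)c1`) gives 63200 nM and compound 2 (`CCCCCCCC(c1c[nH]c2ccc(Br)cc12)c1c[nH]c2ccc(Br)cc12`) gives 1300 nM. That is a 49-fold lower number from compound 1 to compound 2 (1.69 log units; beyond the scatter), a large step beyond the scatter, for heptyl in place of 2,4-dimethoxyphenyl. It was measured on a different core and with a different departing group, so it transfers only loosely. A large move to a lower number in this assay is expected. The estimated step is an at least 12-fold lower number from compound 3 to compound 4 (1.09 log units; beyond the scatter). For compound 4 the expected value is 8000 nM, with an estimated range from 1500 nM to 50000 nM.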

Compound 4, half-maximal inhibitory concentration: 7000 nM
Estimate against measurement, compound 4: 1.1-fold (0.06 log units) above; low and high end bracket the measured number.
By their numbers in this assay, from the lowest: compound 2; then compound 4; then compound 1. At a limit, above all of these: compound 3.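

In this assay, heptyl in place of 4-chlorophenyl on a saturated chain carbon bound to two aromatic carbons gives an at least 14-fold lower number from compound 3 to compound 4 (1.15 log units; beyond the scatter). The move to a lower number with heptyl, so far seen only against 2,4-dimethoxyphenyl on the core of compound 1, now recurs on a second core and against a second departing group. The value of compound 3 is a limit and not a number, so this step gives only a minimum size: the limit of > 100000 nM in this assay, at which 1 of the 4 values shown sits.

Going by these compounds, whether a shorter or longer chain at this carbon would move the number further remains open. So does the effect of an amine or a carboxylic acid at the end of the heptyl chain.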